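Trifluoromethyl on the Benzo Ring of the Shared Core

The source may report more compounds than this note shows. Statements on the series, on what has been measured and on what is new or still open speak of the compounds shown alone.

Measured so far:
compound 1 `CC(C)(O)c1cncc(-n2ncc3ccccc32)c1`: 15 nM
compound 2 `CC(C)(O)c1cncc(-n2nc(C(F)(F)F)c3ccccc32)c1`: 300 nM
compound 3 `CC(C)(O)c1cncc(-n2ncc3cccc(F)c32)c1`: 0.9 nM

All three compounds share one core and were tested in an assay on cells for inhibition of cytochrome P450 11B2, mitochondrial (Homo sapiens), read by HTRF, with stated times of 1 h and 3 h; a lower number here means a stronger inhibitor, a higher number a weaker inhibitor. Compound 1 gives 15 nM, which is the second highest of the three numbers: compound 3 lies well below it and compound 2 well above it. Compound 4 `CC(C)(O)c1cncc(-n2ncc3ccc(C(F)(F)F)cc32)c1` differs from compound 1 by trifluoromethyl in place of hydrogen on an aromatic carbon.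

Going by the values given here, two measured steps bear on this change, neither of them exactly. The step of a 20-fold higher number from compound 1 to compound 2 (1.30 log units; beyond the scatter) puts the same trifluoromethyl group on a different ring of the core. The step of a 17-fold lower number from compound 1 to compound 3 (1.22 log units; beyond the scatter) places a different group, fluoro, on the same six-membered carbon ring but at another site. Both steps were large, yet they pulled in opposite directions, so the new step cannot be read off directly. A moderate weakening is expected for compound 4, in the form of a 2.7-fold higher number from compound 1 to compound 4 (0.43 log units; beyond the scatter). Compound 4 is therefore estimated at 40 nM, within a range from 8 nM to 200 nM.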

Compound 4, half-maximal inhibitory concentration: 2300 nM
Beside the measured number, compound 4's estimate is 58-fold (1.76 log units) below it, and the stated range ends below it.
By their numbers in this assay, from the lowest: compound 3; then compound 1; then compound 2; then compound 4.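

In this assay, trifluoromethyl at this site on the six-membered aromatic ring of carbon only gives a 150-fold higher number from compound 1 to compound 4 (2.19 log units; beyond the scatter) and so costs far more than the same group on a different ring of the core, where the earlier data showed a 20-fold higher number from compound 1 to compound 2 (1.30 log units; beyond the scatter) for that change. The six-membered ring also cannot be read as one uniform region: a 17-fold lower number from compound 1 to compound 3 (1.22 log units; beyond the scatter) came with fluoro at another site, although that step changes both the group and the site. Nothing measured here explains the size of this loss.

Still open, going by these compounds, is whether the loss belongs to trifluoromethyl itself or to any group at this site. Fluoro, methyl or methoxy at this same carbon would help separate those two readings, and an amine would extend the comparison further.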